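The source may hold more compounds than are shown below. What is called first, only, known or untested is meant among the compounds shown, and "the series" means these compounds.

Of the compounds shown here, three have been measured in an ADME assay on Huh-7 cells (Homo sapiens) for cytotoxicity; on this read-out lower numbers stand for higher toxicity in this test and higher numbers for lower toxicity in this test. Compound 1 `Cc1ccccc1-c1nn(-c2ccc(F)cc2F)cc1CNCCN1CCCCC1` reaches only the limit of the test, > 20000 nM. Compound 2 `CN1CCN(CCCNCc2cn(-c3ccc(C(F)(F)F)cc3)nc2-c2ccc(C(F)(F)F)cc2)CC1` gives 2000 nM in this assay. Compound 3 `COc1ccc(-n2cc(CNCCN3CCN(C)CC3)c(-c3ccccc3C)n2)cc1` likewise stops at the limit, > 20000 nM. The data are thus dominated by the limit of > 20000 nM in this assay, at which 2 of the 3 values shown sit, and compound 3 can be placed only as a limit, not as a number. Compound 4 `CCOC(=O)Cn1cc(CNCCN2CCN(C)CC2)c(-c2ccccc2C)n1` differs from compound 3 in one place: (ethoxycarbonyl)methyl in place of 4-methoxyphenyl on an aromatic nitrogen The group that leaves carries one six-membered aromatic ring of carbon only, while the group that enters has no ring. For the measured compounds named here, with no measured step of this kind to lean on, the expected change in this assay is none beyond the scatter, a step that the limit leaves unreadable from compound 3 to compound 4. Compound 4 is therefore estimated at 25000 nM, within 8000 nM to 80000 nM.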

Compound 4, half-maximal cytotoxic concentration: > 20000 nM
Compound 4 gave a limit, no number; the forecaster's own chance of this, stated with the estimate: 70%; the middle value is on the limit's open side.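

Compound 3 and compound 4 both stop at a limit, so no step can be read between them: the limit of > 20000 nM in this assay, at which 3 of the 4 values shown sit.

The compounds shown leave open how far this assay responds to (ethoxycarbonyl)methyl in place of 4-methoxyphenyl on an aromatic nitrogen.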